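The source may hold more compounds than are shown below. What is called first, only, known or untested is meant among the compounds shown, and "the series" means these compounds.

In an ADME assay on L6 cells (Rattus norvegicus) for cytotoxicity (a higher number here means a weaker inhibitor, a lower number a stronger inhibitor), compound 1 `N=C(N)c1cccc(-c2cc3cc(C(=N)N)ccc3o2)c1` gives 21200 nM. Compound 2 `N=C(N)c1ccc(-c2cc3ccc(C(=N)N)cc3o2)cc1` gives 800 nM, so compound 1 holds the higher of the two exact numbers, and the gap between them lies beyond the usual scatter. Compound 3 `Oc1cc(C2=NCCN2)cc2cc(-c3ccc(C4=NCCN4)cc3)oc12` is reported only as a limit, > 203000 nM. Compound 4 `COc1ccc(C(=N)N)cc1-c1cc2cc(C(=N)N)ccc2o1` keeps the structure of compound 1 but has methoxy in place of hydrogen on an aromatic carbon. Going by the values given here, no measured pair shows this change, so no step beyond the scatter is expected in this assay, although the wide spread of these few values calls for a broad range. The expected step is a 1.0-fold higher number from compound 1 to compound 4 (0.02 log units; within the scatter). For compound 4 the estimated value is 22000 nM, with an expected range from 5000 nM to 100000 nM.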

Compound 4, half-maximal inhibitory concentration: 179000 nM
Estimate against measurement, compound 4: 8.1-fold (0.91 log units) below; the whole stated range lies below it.
By their numbers in this assay, from the lowest: compound 2; then compound 1; then compound 4. At a limit, above all of these: compound 3.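

Going by these compounds alone, this is the first step in this assay that isolates a single change: methoxy in place of hydrogen, on an aromatic carbon ortho to a large group and para to a group of 3 heavy atoms, gives an 8.4-fold higher number from compound 1 to compound 4 (0.93 log units; beyond the scatter). This one change at this position is enough to shift the core of compound 1 toward weaker inhibition. Readings in this assay can also end in a limit rather than a number: the limit of > 203000 nM in this assay, at which 1 of the 4 values shown sits.

From the compounds shown here alone, whether the rise is specific to methoxy stays open. A fluorine atom or an amine on the same carbon would help to show this.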